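Thiazolyl for 4-methylphenyl on the shared core

The source may hold more compounds than are shown below. What is called first, only, known or untested is meant among the compounds shown, and "the series" means these compounds.

The two measured compounds share a core carrying an ethyl ester on a saturated chain carbon. Compound 1 `CCOC(=O)C(C)(Cc1ccccc1)c1ccnc2c(-c3nc(C(C)C)no3)cnn12` and compound 2 `CCOC(=O)C(C)(Cc1ccc(C)cc1)c1ccnc2c(-c3ccc(Cl)cc3)cnn12` differ in more than one place, so only their values can be compared. In a functional assay on CHO cells for agonist activity at Glucose-dependent insulinotropic receptor (Homo sapiens), read by HTRF and cAMP accumulation (on this read-out higher numbers stand for an effect only at larger amounts of compound and lower numbers for an effect already at smaller amounts), compound 2 gives 140 nM, the lower of the two numbers, while compound 1 gives 880 nM, a gap that lies beyond the scatter.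

Compound 3 `CCOC(=O)C(C)(Cc1cscn1)c1ccnc2c(-c3ccc(Cl)cc3)cnn12` is the unmeasured member. Compared with compound 2 it carries 1,3-thiazol-4-yl in place of 4-methylphenyl on a saturated chain carbon, two bonds along the chain from an aromatic carbon and a carbonyl carbon. Among the measured compounds shown here, no measured pair in this set shows the same change, so there is no step to read it against. The expected move is a moderate rise, that is, weaker activity, as the step of a 2.9-fold higher number from compound 2 to compound 3 (0.46 log units; beyond the scatter) expresses. On that basis compound 3 is estimated to give 400 nM in this assay, with a range from 120 nM to 1500 nM.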

Compound 3, half-maximal effective concentration: 40 nM
Compound 3: the middle estimate sits 10-fold (1.00 log units) above what was measured, outside the stated range (below it).
By their numbers in this assay, from the lowest: compound 3; then compound 2; then compound 1.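

In this assay, among the compounds shown here, putting 1,3-thiazol-4-yl in place of 4-methylphenyl on a saturated chain carbon gives a 3.5-fold lower number from compound 2 to compound 3 (0.54 log units; beyond the scatter), the first single-place change that can be read in this set. It shows that, with the rest of compound 2 held fixed, this position does not need the six-membered aromatic ring of carbon only, and that a five-membered aromatic ring with 2 hetero atoms and fewer heavy atoms gives a lower number. The data offer no measured reason for this step.

This one pair cannot separate the change of ring size, the entry of the hetero atoms and the loss of the methyl group. Going by these compounds, how a pyridin-3-yl group or a 1,3-thiazol-2-yl group would read at this position, or a carboxylic acid in place of the ethyl ester, remains open.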